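Removing the methoxymethyl group from compound 2

The source may hold more compounds than are shown below. What is called first, only, known or untested is meant among the compounds shown, and "the series" means these compounds.

In a functional assay on A-375 cells (Homo sapiens) for antiproliferative activity, with a stated time of 72 h (a higher number here means a weaker inhibitor, a lower number a stronger inhibitor), compound 1 `C=C1C=CC(=O)[C@@H]2[C@H](Cc3ccc(OCOC)cc3)CC[C@H]12` gives 77.4 nM while compound 2 `C=C1C=CC(=O)[C@@H]2[C@H](Cc3ccc(OCOC)c(F)c3)CC[C@H]12` gives 40 nM and compound 3 `C=C1C=CC(=O)[C@@H]2[C@H](Cc3ccccc3)CC[C@H]12` gives 237 nM on the same scale. The values of compound 2 and compound 1 lie within the scatter of each other, and compound 3 carries the highest number of the three. The step that links the first two, fluoro in place of hydrogen on an aromatic carbon, reads a 1.9-fold lower number from compound 1 to compound 2 (0.29 log units; within the scatter) and so shows no clear change.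

Compound 4 `C=C1C=CC(=O)[C@@H]2[C@H](Cc3ccc(O)c(F)c3)CC[C@H]12` is compound 2 with hydrogen in place of methoxymethyl on an oxygen on an aromatic ring, a change counted as hydrogen in place of methoxymethyl on an oxygen on an aromatic ring that turns methoxymethoxy to hydroxy. For the measured compounds named here, no measured pair shows this exact change. The nearest is hydrogen in place of methoxymethoxy on an aromatic carbon, which takes the oxygen away as well, whereas compound 4 retains it. That step to compound 3 reads a 3.1-fold higher number from compound 1 to compound 3 (0.49 log units; beyond the scatter) and serves as an outer guide, so a smaller move toward a higher number is expected. The estimated step is a 1.9-fold higher number from compound 2 to compound 4 (0.27 log units; within the scatter) in this assay and it remains an expectation only. For compound 4 the estimated value is 75 nM with an expected range from 25 nM to 220 nM in this measurement.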

Compound 4, half-maximal inhibitory concentration: 98.4 nM
Estimate against measurement, compound 4: 1.3-fold (0.12 log units) below; measured number inside the range.
By their numbers in this assay, from the lowest: compounds 2, 1 and 4 (each within the scatter of the next, the first and the last beyond it); then compound 3.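

For the compounds shown here, the change from methoxymethoxy to hydroxy is the first one here that removes the methoxymethyl alone and keeps the oxygen on the aromatic ring, and in this assay it reads a 2.5-fold higher number from compound 2 to compound 4 (0.39 log units; beyond the scatter), a modest step. The earlier compounds shown here showed only the loss of the whole methoxymethoxy group, in the series without fluoro, so they could not show whether the methoxymethyl itself counted at this oxygen; this pair shows that, with fluoro present, losing those atoms alone is enough to raise the number beyond the scatter. Nothing in the material shown gives any measured property that would account for this step, so it stands as an observation of activity only.

Hydroxy appears here only together with fluoro, so the compounds shown leave open whether the same step would be seen with hydrogen in place of that fluoro. They also leave open how a plain methoxy, a longer chain such as ethoxy or an amine would read at this position on the ring, and thus whether the methoxymethyl has any special standing among such groups.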